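A few compounds are considered here, and "the series" means these few. Any claim that something is new, unique, unknown or untested is made for them only; others in the source may bear on it.

Measured so far in a physicochemical assay for lipophilicity; a higher number here means a more lipophilic compound, a lower number a more polar compound:
- compound 1 `C[C@H]1CC[C@@H]2[C@@H](OC(=O)[C@]23CC(c2ccc(Cl)cc2)N(c2ccccc2)O3)[C@]2(C)C(=O)C=C[C@@]12O`: 3.87
- compound 2 `C[C@H]1CC[C@@H]2[C@@H](OC(=O)[C@]23CC(c2ccc(C#N)cc2)N(c2ccccc2)O3)[C@]2(C)C(=O)C=C[C@@]12O`: 2.94
- compound 3 `C[C@H]1CC[C@@H]2[C@@H](OC(=O)[C@]23CC(c2c(Cl)cccc2Cl)N(c2ccccc2)O3)[C@]2(C)C(=O)C=C[C@@]12O`: 4.45

Of the three, compound 3 stands highest at 4.45. Compound 4 `COc1ccc(C2C[C@@]3(ON2c2ccccc2)C(=O)O[C@@H]2[C@H]3CC[C@H](C)[C@]3(O)C=CC(=O)[C@@]23C)cc1Br` has not been measured. It differs from compound 3 by 3-bromo-4-methoxyphenyl in place of 2,6-dichlorophenyl on a saturated ring carbon, with 3-bromo-4-methoxyphenyl in place of 2,6-dichlorophenyl on a saturated ring carbon. Two measured steps change the group on that carbon: the modest a number 0.58 log units higher from compound 1 to compound 3 (beyond the scatter) and the large a number 1.51 log units higher from compound 2 to compound 3 (beyond the scatter). Neither brings in the entering group. The expectation rests on compound 1, whose 4-chlorophenyl group gives 3.87, and a modest fall in this assay is expected. The expected step is a number 0.40 log units lower from compound 3 to compound 4 (beyond the scatter). The estimate for compound 4 is 4.05, within 3.65 to 4.45.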

Compound 4, partition coefficient: 3.98
The estimate for compound 4 lay 0.07 log units above the measured number, within the range that was stated.
By their numbers in this assay, from the lowest: compound 2; then compounds 1 and 4 (each within the scatter of the next); then compound 3.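

In this assay the step is a number 0.11 log units higher from compound 1 to compound 4 (within the scatter), so on this saturated ring carbon 3-bromo-4-methoxyphenyl cannot be told apart from 4-chlorophenyl. The group still stands clearly below 2,6-dichlorophenyl, with a number 0.47 log units lower from compound 3 to compound 4 (beyond the scatter), and clearly above 4-cyanophenyl, with a number 1.04 log units higher from compound 2 to compound 4 (beyond the scatter). Nothing available here accounts for these differences. The compounds shown leave open what the bromine and the methoxy each contribute alone. They also leave open where an amine or a carboxylic acid on this aromatic ring would stand.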